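What replacing the acetyl group may do to cell tolerance

This account rests on a few compounds, and the source may have more. Where it says the series, first, only, none or still open, it means among the compounds named here.

Compound 1 `COc1ccc(-c2nc3cc(C(C)=O)ccc3[nH]2)c(OC)c1`: 50000 nM
Compound 2 `COc1ccc(-c2nc3cc(C(C)=O)ccc3[nH]2)c(OC)c1OC`: > 100000 nM (a limit)
Compound 3 `C/C(=N\NC(N)=S)c1ccc2[nH]c(-c3ccc(C(F)(F)F)cc3)nc2c1`: 2000 nM

Among the two exact numbers in an ADME assay on MT4 cells (Homo sapiens) for cytotoxicity, read by MTT assay, with a stated time of 96 h (a lower number here means that less compound is tolerated, a higher number that more compound is tolerated), the higher belongs to compound 1 at 50000 nM and the lower to compound 3 at 2000 nM. Compound 2 gives only a limit of the assay, > 100000 nM.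

The next compound, compound 4 `COc1ccc(-c2nc3cc(/C(C)=N/NC(N)=S)ccc3[nH]2)c(OC)c1`, keeps the core of compound 1 but replaces its acetyl group, on an aromatic carbon, with a larger group: a group of 7 heavy atoms (3 carbon, 3 nitrogen, 1 sulfur; no ring) in place of a group of 3 heavy atoms (2 carbon, 1 oxygen; no ring), on an aromatic carbon.

Within the data shown here, the only measured step, an at least 2.0-fold higher number from compound 1 to compound 2 (0.30 log units; that floor lies within the scatter), puts a methoxy in place of hydrogen on an aromatic carbon. That is a different change, which leaves the acetyl untouched, so it offers little guidance here. A better clue is compound 3, which already carries the same new group and sits at 2000 nM. However, compound 3 also has trifluoromethyl where compound 1 has its methoxy groups, so the comparison is loose. In this assay, a move to a lower number is therefore expected, meaning that less compound would be tolerated. The estimated change is a 6.3-fold lower number from compound 1 to compound 4 (0.80 log units; beyond the scatter). For compound 4 the expected value is 8000 nM, with an estimated range from 2000 nM to 40000 nM.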

Compound 4, half-maximal cytotoxic concentration: 72000 nM
Estimate against measurement, compound 4: 9.0-fold (0.95 log units) below; measured number outside the range, above it.
By their numbers in this assay, from the lowest: compound 3; then compounds 1 and 4 (each within the scatter of the next). At a limit, above all of these: compound 2.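

On the core of compound 1, putting the larger group in place of the acetyl on this aromatic carbon gives a 1.4-fold higher number from compound 1 to compound 4 (0.16 log units; within the scatter) in this assay, so the two compounds cannot be told apart here. Compound 3 alone had suggested a link between this group and a low number, with its value of 2000 nM, but compound 4 carries the same group without such a value, which shows that the group does not go with a low number on every core, although compound 3 also has trifluoromethyl where compound 4 has its methoxy groups. Compound 2 alone stands at a limit, and compound 4 gives an exact number: the limit of > 100000 nM in this assay, at which 1 of the 4 values shown sits.

What the compounds shown leave open is which part of compound 3 goes with its value, since trifluoromethyl and the new group are not separated in any single step here. From the compounds shown here alone, it also remains open how this position would respond to a different kind of group, such as an amine, a carboxylic acid or a longer chain, and whether the new group would behave the same way on the core of compound 2.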